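The source may hold more compounds than are shown below. What is called first, only, known or untested is meant among the compounds shown, and "the series" means these compounds.

In an ADME assay on MRC5 cells (Homo sapiens) for antiproliferative activity, read by fluorescence and resazurin assay, with a stated time of 68 h (on this read-out lower numbers stand for an effect already at smaller amounts and higher numbers for an effect only at larger amounts of compound), compound 1 `Cc1ccc(-c2cc(C(=O)Nc3cccnc3)c3cc(Cl)ccc3n2)cc1` gives 21000 nM as its half-maximal effective concentration. Compound 2 `Cc1ccc(-c2cc(C(=O)Nc3cccnc3)c3ccccc3n2)cc1` reaches only a limit of the assay, reported as > 50000 nM and not as a number. Compound 3 `CN1CCN(c2cc(C(=O)NCCN3CCCC3)c3cc(F)ccc3n2)CC1` gives 20000 nM and so stands level with compound 1 within the usual scatter.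

The next compound is compound 4 `CN(C)c1ccc(-c2cc(C(=O)NCCN3CCCC3)c3cc(F)ccc3n2)cc1`, which differs from compound 3 in one group 4-(dimethylamino)phenyl in place of 4-methylpiperazin-1-yl on an aromatic carbon on an aromatic carbon next to the ring nitrogen, where 4-(dimethylamino)phenyl stands in place of 4-methylpiperazin-1-yl. Within the data shown here, the only measured step, an at least 2.3-fold higher number from compound 1 to compound 2 (0.37 log units; beyond the scatter) for hydrogen in place of chloro, is a different change and gives no direct guide to its size. Compound 1 also carries a six-membered aromatic ring of carbon only at that place and gives 21000 nM in this comparison, but it differs from compound 3 elsewhere too. Compound 2 carries such a ring as well, yet it sits at the limit of > 50000 nM in this assay, at which 1 of the 3 values shown sits, and so goes against any simple reading.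

No step beyond the scatter is therefore expected in this assay for this change, the estimated step being a 1.3-fold lower number from compound 3 to compound 4 (0.12 log units; within the scatter) with a wide margin. The estimate for compound 4 is 15000 nM as the expected value, within an expected range from 5000 nM to 50000 nM for repeated measurements.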

Compound 4, half-maximal effective concentration: 10000 nM
Estimate against measurement, compound 4: 1.5-fold (0.18 log units) above; the range from low to high includes it.
By their numbers in this assay, from the lowest: compounds 4, 3 and 1 (each within the scatter of the next, the first and the last beyond it). At a limit, above all of these: compound 2.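

In this assay, placing 4-(dimethylamino)phenyl where 4-methylpiperazin-1-yl stood, on the aromatic carbon next to the ring nitrogen, gives a 2.0-fold lower number from compound 3 to compound 4 (0.30 log units; within the scatter). Among these compounds, this is the first measured step at this place, and it shows that a non-aromatic ring with two hetero atoms and a six-membered aromatic ring of carbon only, the entering group being the larger by its heavy atoms, can stand here without a change beyond the usual scatter. The step sits at the edge of that scatter, so it supports no ranking of the two groups, and nothing measured here points to a cause for its size.

The compounds shown leave open whether this holds for other groups at this place, such as morpholin-4-yl, a simple primary amine, or a phenyl ring carrying a carboxylic acid. This single pair shares the fluoro group and the amide side chain of compound 3, so it also leaves open whether the same exchange would behave alike with a chloro group on the core or a longer chain on the amide.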